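This account rests on a few compounds, and the source may have more. Where it says the series, first, only, none or still open, it means among the compounds named here.

Working notes, values in an ADME assay on L6 cells (Rattus norvegicus) for cytotoxicity, read by resazurin assay, with a stated time of 70 h; on this read-out lower numbers stand for stronger inhibition and higher numbers for weaker inhibition:
- compound 1 `CC(=O)Oc1ccc2c(c1)C(C)=CC(C)(C)N2Cc1ccc(C(F)(F)F)cc1`: 14000 nM
- compound 2 `CC(=O)Oc1ccc2c(c1)C(C)=CC(C)(C)N2Cc1ccc(F)cc1`: 29000 nM
- compound 3 `CC(=O)Oc1ccc2c(c1)C(C)=CC(C)(C)N2Cc1ccc(C(C)(C)C)cc1`: not yet measured

Compound 2 stands highest of the two measured compounds at 29000 nM, with compound 1 the nearest at 14000 nM.

The next change replaces fluoro with tert-butyl on an aromatic carbon, para to a large group: tert-butyl in place of fluoro on an aromatic carbon.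

For the measured compounds named here, one measured step bears on it, and it concerns the same place: a 2.1-fold higher number from compound 1 to compound 2 (0.32 log units; beyond the scatter). That step is modest, and compound 2, the fluoro member, carries the higher number. Going by the values given here, no measured compound yet has tert-butyl, so the evidence is thin.

A modest move to a lower number in this assay is expected, and the estimated step is a 2.1-fold lower number from compound 2 to compound 3 (0.32 log units; beyond the scatter). The expected value for compound 3 is 14000 nM, with an estimated range from 5000 nM to 32000 nM.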

Compound 3, half-maximal inhibitory concentration: 9000 nM
Compound 3: middle estimate off by 1.6-fold (0.19 log units), on the high side; low and high end bracket the measured number.
By their numbers in this assay, from the lowest: compounds 3 and 1 (each within the scatter of the next); then compound 2.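

Replacing fluoro with tert-butyl gives a 3.2-fold lower number from compound 2 to compound 3 (0.51 log units; beyond the scatter) in this assay and so shows that fluoro, on an aromatic carbon para to a large group, carries a higher number than two other groups at this place, not just trifluoromethyl. The comparison of the other two groups, a 1.6-fold lower number from compound 1 to compound 3 (0.19 log units; within the scatter) in this assay, gives no order between tert-butyl and trifluoromethyl, although tert-butyl enters with 4 heavy atoms of carbon. No accompanying measurement offers an explanation for the position of the fluoro member.

On these data alone, it remains open whether a group such as an amine, a carboxylic acid or a longer chain at this place would fall with the fluoro member or with the other two. The three compounds also leave open whether the same order would hold on a different core.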